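The source may report more compounds than this note shows. Statements on the series, on what has been measured and on what is new or still open speak of the compounds shown alone.

Working notes on the series. Compound 1, `Cc1ccc(-c2cn(-c3ccc(CN4CCN(C)CC4)cc3)nn2)cc1Nc1nccc(-c2cccnc2)n1`, gives 4700 nM in a functional assay on K562 cells (Homo sapiens) for inhibition, read by MTT assay, with a stated time of 72 h; on this read-out lower numbers stand for stronger inhibition and higher numbers for weaker inhibition. Compound 2, `Cc1ccc(-n2cc(C(C)O)nn2)cc1Nc1nccc(-c2cccnc2)n1`, gives 15300 nM in this assay. Compound 3, `Cc1ccc(-c2nnc(-c3cccnc3)o2)cc1Nc1nccc(-c2cccnc2)n1`, is reported only as a limit of this assay, > 30000 nM, and not as a number. Where compound 3 stands among the three values shown is therefore set by the limit of > 30000 nM in this assay, at which 1 of the 3 values shown sits; compound 1 and compound 2 each show a number, compound 3 does not, and no step between any two of these compounds has been worked out. Nothing in the recorded values ties the step from compound 3 to compound 4 to an observed change.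

Compound 4, `Cc1ccc(-c2nnc(-c3ccc(F)c(C(F)(F)F)c3)o2)cc1Nc1nccc(-c2cccnc2)n1`, is not yet measured in this assay. It differs from compound 3 in one place: 4-fluoro-3-(trifluoromethyl)phenyl in place of pyridin-3-yl on an aromatic carbon. Since compound 3 sits at a limit, any step to compound 4 can only be read as a move into the measurable range or not; there is no measured number to compare against. A direction is therefore taken as a guess rather than from an observed step, and the expected step is an at least 2.0-fold lower number from compound 3 to compound 4 (0.30 log units; that floor lies within the scatter).

Compound 4 is expected to give about 15000 nM in this assay, within the range of 3000 nM to 60000 nM.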

Compound 4, half-maximal inhibitory concentration: 29700 nM
Compound 4: middle estimate off by 2.0-fold (0.30 log units), on the low side, within the range that was stated.
By their numbers in this assay, from the lowest: compound 1; then compounds 2 and 4 (each within the scatter of the next). At a limit, above all of these: compound 3.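

In this assay, putting 4-fluoro-3-(trifluoromethyl)phenyl in place of pyridin-3-yl on the aromatic carbon next to the ring oxygen and the ring nitrogen gives a number no higher from compound 3 to compound 4 (the limit leaves the size open). With compound 4 at 29700 nM, this position on the five-membered aromatic ring now has a readable number, and it shows that a ring of carbon only, carrying fluorine and trifluoromethyl and with no ring nitrogen, is compatible with a measurable value in this assay. The change cannot be sized, and no gain can be claimed for the new group, because compound 3 is held only at a limit of the assay and not at a number: the limit of > 30000 nM in this assay, at which 1 of the 4 values shown sits.

The compounds shown leave open whether the 4-fluoro or the 3-trifluoromethyl substituent matters more, since an unsubstituted phenyl or a phenyl bearing only one of the two would be needed to separate them. They also leave open how this position responds to a group of a different kind, such as a primary amine, a carboxylic acid or a morpholine ring on the phenyl.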